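A few compounds are considered here, and "the series" means these few. Any claim that something is new, unique, unknown or untested is made for them only; others in the source may bear on it.

Measured compounds in a functional assay on EC9706 cells (Homo sapiens) for cytotoxicity, read by MTT assay, with a stated time of 72 h; a lower number here means a stronger inhibitor, a higher number a weaker inhibitor:

- compound 1, `O=C(CSC(=S)N[C@H]1CCOC1=O)Nc1ccccc1F`; in this assay compound 1 gives > 128000 nM, which is a limit of the assay and not a number.
- compound 2, `O=C(CSC(=S)N[C@H]1CCOC1=O)Nc1cccc(Cl)c1`; in this assay compound 2 gives 107000 nM.

Among the compounds with values here, compound 2 therefore stands as the only numbered value in this assay; the other value shown sits at the limit of > 128000 nM in this assay, at which 1 of the 2 values shown sits. Within the data shown here, the single measured step, an at least 1.1-fold lower number from compound 1 to compound 2 (0.07 log units; that floor lies within the scatter), sets only a floor, and that floor lies within the scatter, so it gives no direction beyond noise for a change on the phenyl ring.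

Compound 3, `O=C(CSC(=S)N[C@H]1CCOC1=O)Nc1cccc([N+](=O)[O-])c1`, is the next member. Its change from compound 2 is nitro in place of chloro on an aromatic carbon. Among the measured compounds shown here, the only measured step that bears on it is the one from compound 1 to compound 2, which exchanged one halogen-bearing phenyl for another and resolved nothing beyond the scatter. Nothing shown speaks for a nitro group shifting the number in either direction, so the step from compound 2 to compound 3 is expected to be a 1.1-fold lower number from compound 2 to compound 3 (0.03 log units; within the scatter), none beyond the scatter. Compound 3 is accordingly estimated at 100000 nM, within 40000 nM to 250000 nM.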

Compound 3, half-maximal inhibitory concentration: > 128000 nM
Compound 3: no number, only a limit; the forecaster's own chance of this, stated with the estimate: 35%; middle value at least 1.2-fold (0.10 log units) away from the limit.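

In this assay compound 3 gives > 128000 nM, which is a limit of the assay and not a number. The step reads an at least 1.1-fold higher number from compound 2 to compound 3 (0.07 log units; that floor lies within the scatter), so nitro in place of chloro on an aromatic carbon, meta to a large group, sets only a floor that shows no change beyond the scatter, and the true size of the step cannot be read. The new result adds a second group at this position, and of the two only chloro, in compound 2, gives a number, while the series otherwise gathers at one limit: the limit of > 128000 nM in this assay, at which 2 of the 3 values shown sit.

Still open, going by these compounds, is whether any group at this aromatic carbon can move the number clearly away from that of compound 2, for example an amine, a methoxy group or a carboxylic acid. Within the data shown here, also open is whether the series responds at all to changes away from the phenyl ring, such as a longer chain between the sulfur and the amide carbonyl, since every step so far stays within the scatter or cannot be read beyond it.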